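A Ring Swap on a Shared Core and Cytotoxicity

The compounds below may be only part of what the source reports. "The series", "measured", "known", "first", "only" and "open" are said of these compounds alone.

Compound 1 `O=C1Nc2ccccc2/C1=N/NC(=S)Nc1ccc(Cl)cc1` was examined in an ADME assay on RD cells (Homo sapiens) for cytotoxicity; on this read-out lower numbers stand for higher toxicity in this test and higher numbers for lower toxicity in this test. In this test compound 1 gives > 25000 nM, which is a limit of the assay rather than a number. Compound 2 `O=C1Nc2ccccc2/C1=N/NC(=S)N1CCCC1` was measured in the same way. In this assay compound 2 gives > 25000 nM, again a limit and not a number. Both values sit at the limit of > 25000 nM in this assay, at which 2 of the 2 values shown sit, so compound 1 stands at the boundary of the range, with no numerical value of its own to set against compound 2.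

Compound 3 `Cc1ccccc1NC(=S)N/N=C1\C(=O)Nc2ccccc21` has not yet been measured. It differs from compound 1 by 2-methylphenyl in place of 4-chlorophenyl on an amide-type nitrogen. Going by the values given here, no step between measured compounds that differ in a single place has been recorded, so there is nothing to gauge the size of this change against. Because compound 1 sits at the limit of > 25000 nM in this assay, at which 2 of the 2 values shown sit, the expected step that the limit leaves unreadable from compound 1 to compound 3 is none beyond the scatter. The expectation for compound 3 in this assay is a value of 30000 nM, between 15000 nM and 60000 nM, most likely reported once more as a limit.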

Compound 3, half-maximal cytotoxic concentration: > 25000 nM
Compound 3 gave a limit, no number; the forecaster's own chance of this, stated with the estimate: 80%; the middle value is on the limit's open side.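

Going by these compounds alone, no step from compound 1 to compound 3 can be read, since both are reported only as limits: (the limit of > 25000 nM in this assay, at which 3 of the 3 values shown sit). The compounds shown leave open whether 2-methylphenyl in place of 4-chlorophenyl changes the read-out in this assay at all, and how far any of them lies beyond that limit.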